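The source may report more compounds than this note shows. Statements on the series, on what has been measured and on what is new or still open speak of the compounds shown alone.

Among the three measured compounds, compound 1 `CC(c1ccc(-c2ccccc2)c(F)c1)c1nnc2n1N=C(c1ccc(Cl)cc1Cl)CS2` stands lowest in a functional assay on Huh-7 cells (Homo sapiens) for inhibition, read by sulforhodamine B assay, with a stated time of 72 h; a lower number here means a stronger inhibitor, a higher number a weaker inhibitor: compound 1 gives 3700 nM. The nearest of the other two is compound 3 `COc1ccc2cc(C(C)c3n[nH]c(=S)n3N)ccc2c1`, which in this assay gives 40800 nM, a gap that lies beyond the usual scatter. Furthest away is compound 2 `CC(c1ccc(-c2ccccc2)c(F)c1)c1n[nH]c(=S)n1N`, which gives 43100 nM, again beyond the scatter. Compound 2 and compound 3 share a smaller core, while only compound 1 carries the fused or bridged system of two rings, so on these three numbers compound 1 is the strongest inhibitor.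

Compound 4 `CC(c1ccc(-c2ccccc2)c(F)c1)c1nnc2n1N=C(c1ccc(Br)cc1)CS2` keeps that fused core and differs from compound 1 in one place: 4-bromophenyl in place of 2,4-dichlorophenyl on a carbon with a double bond to nitrogen. For the measured compounds named here, no pair of measured compounds differs at this position alone, so the size of the step cannot be read off from an earlier example. One halogenated phenyl is exchanged for another, with one fewer heavy atom. The expected step from compound 1 to compound 4 is a 1.4-fold higher number from compound 1 to compound 4 (0.13 log units; within the scatter), a small move toward a somewhat higher number that may not clear the scatter. Compound 4 is therefore estimated at 5000 nM, within a range from 1500 nM to 16000 nM.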

Compound 4, half-maximal inhibitory concentration: 5000 nM
For compound 4 middle estimate and measured number coincide at the digits printed; the measured number falls inside the stated range.
By their numbers in this assay, from the lowest: compounds 1 and 4 (each within the scatter of the next); then compounds 3 and 2 (each within the scatter of the next).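

In this assay, for the compounds shown here, the exchange of 2,4-dichlorophenyl for 4-bromophenyl on a carbon with a double bond to nitrogen is a 1.4-fold higher number from compound 1 to compound 4 (0.13 log units; within the scatter), the first step that can be read at this position, as no earlier pair differed here alone. It shows that, with the rest of compound 1 held constant, this one halogenated phenyl can stand in for the other, with one heavy atom fewer, without a change that clears the usual scatter, so the two groups cannot be told apart in this assay. No measurement of any property of these groups or of the compounds bears on this result.

Because both groups are halogenated phenyl rings, the compounds shown leave open how far this position tolerates other groups, such as an unsubstituted phenyl, a 4-methoxyphenyl, a pyridine ring or a phenyl carrying a carboxylic acid or an amine. They also leave open what each part of the exchange contributes on its own, which a 4-chlorophenyl group at the same place would help to separate.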